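A Fluoro for Chloro Swap at Compound 2

The source may hold more compounds than are shown below. What is called first, only, known or untested is meant among the compounds shown, and "the series" means these compounds.

Of the compounds shown here, two have so far been measured in a functional assay on SF-295 cells (Homo sapiens) for antiproliferative activity; a higher number here means a weaker inhibitor of growth, a lower number a stronger inhibitor of growth. There, compound 1 (`Cc1ccc2c(O)cc(-c3cccc(Cl)c3)nc2n1`) gives 22.9 nM and compound 2 (`Cc1cnc2[nH]c(-c3cccc(Cl)c3)cc(=O)c2c1`) gives 25.1 nM and these two values lie within the scatter of each other. Compound 2 therefore holds the higher number only nominally, and the pair stands together in the same range.

The next compound, compound 3 (`Cc1cnc2[nH]c(-c3cccc(F)c3)cc(=O)c2c1`), departs from compound 2 at a single place (fluoro in place of chloro on an aromatic carbon). It carries fluoro in place of chloro on an aromatic carbon, meta to a large group.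

Among the compounds with values here, no two measured compounds differ in only one place, so the data give no direct measure of this swap. A small change is expected in this assay, leaning toward a somewhat higher number and possibly staying within the scatter. The estimated move is a 1.4-fold higher number from compound 2 to compound 3 (0.14 log units; within the scatter) and no large shift is anticipated. Compound 3 is expected at 35 nM with an estimated range from 12 nM to 100 nM as its likely span.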

Compound 3, concentration for 50% growth inhibition: 27.5 nM
The estimate for compound 3 lay 1.3-fold (0.10 log units) above the measured number; low and high end bracket the measured number.
By their numbers in this assay, from the lowest: compounds 1, 2 and 3 (each within the scatter of the next).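

In this assay, within the data shown here, this swap gives the first comparison of compounds that differ in one place: a 1.1-fold higher number from compound 2 to compound 3 (0.04 log units; within the scatter), for fluoro in place of chloro on an aromatic carbon, meta to a large group. Compound 2 and compound 3 therefore cannot be told apart in this assay, and at this position on the six-membered aromatic ring of carbon only, chloro and fluoro stand in the same range. The data offer no explanation for why the two groups read alike.

The compounds shown leave open how far this sameness extends, as only chloro and fluoro appear at this position, so a methoxy group, an amine or a carboxylic acid on the same aromatic carbon remains an untested kind of substituent in this series. Among these compounds, it also remains open whether fluoro in place of chloro would read the same way on the core of compound 1, since the one step available comes from the core shared by compound 2 and compound 3.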